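The compounds below may be only part of what the source reports. "The series", "measured", "known", "first", "only" and "open" are said of these compounds alone.

Compound 1 `CCOc1ccccc1NC(=O)CSc1c[nH]c2c(Cl)cccc12` and compound 2 `CCOc1ccccc1NC(=O)CSc1c[nH]c2c(OC)cccc12` share a core and are compared in an ADME assay on HEK-293T cells (Homo sapiens) for cytotoxicity, read by CCK-8 assay, with a stated time of 48 h; on this read-out higher numbers stand for lower toxicity in this test and lower numbers for higher toxicity in this test. For compound 1 the assay gives only a limit, > 100000 nM. For compound 2 the assay likewise gives only a limit, > 100000 nM. The change between them is methoxy in place of chloro on an aromatic carbon, and the two limits leave the step that the two limits leave unreadable from compound 1 to compound 2 unreadable, because both values sit at the limit of > 100000 nM in this assay, at which 2 of the 3 values shown sit.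

Compound 3 `O=C(CSc1c[nH]c2cccc(Cl)c12)Nc1ccc(Cl)c(Cl)c1` carries a different core; how that core differs from the core of compound 1 is not broken down here. In this assay, for the measured compounds named here, compound 3 gives 34700 nM, the only real number in the set.

Compound 4 `COc1cccc2[nH]cc(SCC(=O)Nc3ccc(Cl)c(Cl)c3)c12` is still to be measured. It differs from compound 3 by methoxy in place of chloro on an aromatic carbon, the same change as from compound 1 to compound 2. That earlier step gives no readable size, so the expectation for compound 4 rests on the value of compound 3, 34700 nM, with a step of a 1.3-fold higher number from compound 3 to compound 4 (0.11 log units; within the scatter) expected to stay small. For compound 4 the estimated value is 45000 nM, expected between 15000 nM and 100000 nM.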

Compound 4, half-maximal cytotoxic concentration: > 100000 nM
Compound 4 gave a limit, no number (the forecaster's own chance of this, stated with the estimate: 35%); middle value at least 2.2-fold (0.34 log units) away from the limit.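

In this assay, methoxy in place of chloro on an aromatic carbon gives an at least 2.8-fold higher number from compound 3 to compound 4 (0.45 log units; beyond the scatter) on the core of compound 3, a shift towards lower toxicity in this test. As far as these compounds go, compound 4 gives > 100000 nM as a limit and not a number, so the full size of this step stays unknown. This does not show that the change acts alike on both cores, because the step from compound 1 to compound 2 cannot be read, leaving nothing to set this step against: the limit of > 100000 nM in this assay, at which 3 of the 4 values shown sit.

The compounds shown leave open how a group other than chloro or methoxy, such as an amine or a carboxylic acid, would read at this place on the ring. They also leave open whether a longer chain in place of the methoxy would keep the value at the limit, and whether the step seen here would appear on any further core.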